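Replacing Aminocarbamoyl in a Series of Level Doses

A few compounds are considered here, and "the series" means these few. Any claim that something is new, unique, unknown or untested is made for them only; others in the source may bear on it.

In a functional assay on the whole organism with Mus musculus as the target (on this read-out lower numbers stand for an effect already at smaller amounts and higher numbers for an effect only at larger amounts of compound), compound 3 (`CC[C@@H](C(=O)NN)N1CCCC1=O`) gives 1000 umol/kg as its dose, level with compound 1 (`CC[C@@H](C(=O)N(C)OC)N1CCCC1=O`) at 1000 umol/kg and compound 2 (`CC[C@@H](C(=O)NO)N1CCCC1=O`) at 1000 umol/kg on the same read-out. The next structure, compound 4 (`CC[C@@H](C(=N)N)N1CCCC1=O`), loses the aminocarbamoyl on a saturated chain carbon bound to an amide-type nitrogen in a ring and a saturated chain carbon, and carries a group with no common name there instead (a group of 3 heavy atoms (1 carbon, 2 nitrogen; no ring) in place of a group of 4 heavy atoms (1 carbon, 2 nitrogen, 1 oxygen; no ring), on a saturated chain carbon bound to an amide-type nitrogen in a ring and a saturated chain carbon). Going by the values given here, three measured steps bear on this change, each altering what sits on the carbonyl carbon. They show no change at the digits printed from compound 1 to compound 2 (within the scatter) as well as no change at the digits printed from compound 1 to compound 3 (within the scatter) and no change at the digits printed from compound 2 to compound 3 (within the scatter) on this read-out. None of them takes away the oxygen that leaves with the aminocarbamoyl, so they guide the expectation only indirectly. No step beyond the scatter is expected in either direction, and the estimated step is no change at the digits printed from compound 3 to compound 4 (within the scatter) in this assay for now. For compound 4 the estimated dose is 1000 umol/kg with an expected range from 400 umol/kg to 2000 umol/kg in this assay.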

Compound 4, dose for half-maximal effect: 1000 umol/kg
The estimate for compound 4 equals the measured number at the digits printed, within the range that was stated.
By their numbers in this assay, from the lowest: compounds 1, 2, 3 and 4 (each within the scatter of the next).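

Taking away the carbonyl oxygen, which none of the earlier steps did, gives no change at the digits printed from compound 3 to compound 4 (within the scatter) in this assay, and the comparison with the hydroxy amide gives no change at the digits printed from compound 2 to compound 4 (within the scatter) on the same read-out. At this place, on a saturated chain carbon bound to an amide-type nitrogen in a ring and a saturated chain carbon, the dose therefore stays level with or without that oxygen, so all four groups shown fall within the scatter of one another. Nothing measured here accounts for this lack of separation.

All four compounds share one value, so these groups do not reveal whether any change at this place can shift the dose at all. From the compounds shown here alone, a carboxylic acid, a plain amine or a longer chain there could still answer that, and each remains open.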